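Replacing a Hydroxyethyl Chain with a Sulfur-Bearing Group

This account rests on a few compounds, and the source may have more. Where it says the series, first, only, none or still open, it means among the compounds named here.

Compound 1 `Nc1nn2c(O)cc(-c3ccc(F)cc3)nc2c1[N+](=O)[O-]` carries a 4-fluorophenyl group on its core. In a functional assay on L929 cells (Mus musculus) for inhibition (a lower number here means a stronger inhibitor of growth, a higher number a weaker inhibitor of growth), compound 1 gives > 50 ug/mL, which is a limit of the assay rather than a measured number. Compound 2 `Nc1nn2c(O)cc(CNNCCO)nc2c1[N+](=O)[O-]` carries a (((2-hydroxyethyl)amino)amino)methyl chain in that position. In this assay compound 2 gives > 50 ug/mL, again only a limit. Compound 3 `Nc1nn2c(O)cc(CNCCO)nc2c1[N+](=O)[O-]` carries a ((2-hydroxyethyl)amino)methyl chain there. In this assay compound 3 gives > 50 ug/mL, also a limit. The steps a step that the two limits leave unreadable from compound 1 to compound 2, a step that the two limits leave unreadable from compound 1 to compound 3 and a step that the two limits leave unreadable from compound 2 to compound 3 therefore cannot be sized, because of the limit of > 50 ug/mL in this assay, at which 3 of the 3 values shown sit. Compound 3 thus stands where every compound shown here stands, at the limit, with no readable number anywhere in the set.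

Compound 4 `Nc1nn2c(O)cc(CNNC(N)S)nc2c1[N+](=O)[O-]` differs from compound 3 by (amino(sulfanyl)methyl)amino in place of 2-hydroxyethyl on an amine nitrogen. Within the data shown here, no measured step bears on this change with a readable size, since all three steps run between limits. With nothing in the set showing movement, the expected step here is a step that the limit leaves unreadable from compound 3 to compound 4, none beyond the scatter. Compound 4 is expected to give 60 ug/mL in this assay, most likely reported as a limit once more, within a range from 20 ug/mL to 200 ug/mL.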

Compound 4, concentration for 50% growth inhibition: > 50 ug/mL
Compound 4: no number, only a limit; the forecaster's own chance of this, stated with the estimate: 85%; the middle value does not contradict the limit.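

In this assay compound 4 gives > 50 ug/mL, which is a limit of the assay and not a number. The steps from compound 1, compound 2 and compound 3 to compound 4 therefore cannot be read, because all four compounds share one result: the limit of > 50 ug/mL in this assay, at which 4 of the 4 values shown sit. The compounds shown leave open how strongly, if at all, any of these groups changes growth inhibition.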